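A few compounds are considered here, and "the series" means these few. Any claim that something is new, unique, unknown or untested is made for them only; others in the source may bear on it.

Of the compounds shown here, three of the shared core have been measured in a functional assay on MCF7 cells (Homo sapiens) for inhibition, read by sulforhodamine B assay, with a stated time of 48 h; on this read-out lower numbers stand for stronger inhibition of growth and higher numbers for weaker inhibition of growth. Compound 1 `COc1cc(-c2nn(-c3cccc(NC(=O)c4ccc(Cl)c(C(F)(F)F)c4)c3)cc2-c2ccncc2)ccc1Cl` gives 2240 nM, compound 2 `COc1cc(-c2nn(-c3cccc(NC(=O)c4cccc(C(F)(F)F)c4)c3)cc2-c2ccncc2)ccc1Cl` gives 1430 nM, and compound 3 `COc1cc(-c2nn(-c3cccc(NC(=O)Nc4ccc(Cl)c(C(F)(F)F)c4)c3)cc2-c2ccncc2)ccc1Cl` gives 919 nM. Among these three, compound 3 carries the lowest number; its gap to compound 2 lies within the scatter, while its gap to compound 1, a 2.4-fold lower number from compound 1 to compound 3 (0.39 log units; beyond the scatter), lies beyond it. The steps of a 1.6-fold lower number from compound 1 to compound 2 (0.19 log units; within the scatter) and a 1.6-fold lower number from compound 2 to compound 3 (0.19 log units; within the scatter) are both within the scatter. Going by the values given here, every measured step so far concerns the group on a carbonyl carbon.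

Compound 4 `O=C(Nc1cccc(-n2cc(-c3ccncc3)c(-c3ccc(Cl)c(O)c3)n2)c1)Nc1ccc(Cl)c(C(F)(F)F)c1` is the next compound to be measured in this assay. It differs from compound 3 at a different place: hydrogen in place of methyl on an oxygen on an aromatic ring, which read one bond further out is methoxy to hydroxy, or 4-chloro-3-methoxyphenyl to 4-chloro-3-hydroxyphenyl. Among the compounds with values here, none of the measured steps touches this oxygen; the series so far holds no comparison of a methoxy against a hydroxy at this place, so there is no step to lean on. The expectation for this assay is therefore a step of a 1.0-fold higher number from compound 3 to compound 4 (0.01 log units; within the scatter) that stays within the scatter, with no firm direction. Compound 4 is estimated at 950 nM, with a range from 400 nM to 2300 nM.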

Compound 4, concentration for 50% growth inhibition: 663 nM
For compound 4 the middle estimate is 1.4-fold (0.16 log units) above the measured one, and the stated range covers the measured number.
By their numbers in this assay, from the lowest: compounds 4, 3, 2 and 1 (each within the scatter of the next, the first and the last beyond it).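

In this assay, going by these compounds alone, the change from methoxy to hydroxy on the 4-chloro-3-methoxyphenyl group gives a 1.4-fold lower number from compound 3 to compound 4 (0.14 log units; within the scatter), the first reading at this oxygen, as all earlier steps concerned the group on a carbonyl carbon. Hydrogen in place of methyl on this oxygen therefore leaves the growth-inhibition number indistinguishable from that of the methoxy compound, so in this single pair the methyl is not needed to keep the read-out in the same range, and neither methoxy nor hydroxy can be ranked above the other. Nothing at hand bears on what lies behind this result.

As far as these compounds go, this is one pair on one background, so it remains open whether the same change reads alike on compound 1 or compound 2, which carry different groups on the carbonyl carbon. Also open, from the compounds shown here alone, is how far this place accepts other groups, such as an ethoxy or a longer alkoxy chain on the oxygen, or an amine or a carboxylic acid in place of the hydroxy.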